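Methylating an Amide Nitrogen in a Diaryl Core Series

The source may report more compounds than this note shows. Statements on the series, on what has been measured and on what is new or still open speak of the compounds shown alone.

Of the compounds shown here, two of a shared core have been tested in an assay on HeLa cells for displacement of a labelled ligand from adenosine receptor A3 (Homo sapiens), read by fluorescence polarization, with a stated time of 30 min; a lower number here means a stronger inhibitor, a higher number a weaker inhibitor. Compound 1 `COc1ccc(-c2cc(NC(=O)CCC(=O)N(C)CC(=O)NCc3ccccc3)nc(-c3ccc(OC)cc3)n2)cc1` gives 35400 nM in this assay. Compound 2 `COc1ccc(-c2cc(NC(=O)COCC(=O)NCC(=O)NC(C)(C)C)nc(-c3ccc(OC)cc3)n2)cc1` gives 19700 nM in this assay, and these two numbers lie within the usual scatter of each other, so neither compound can be set apart from the other on the evidence at hand.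

Compound 3 `COc1ccc(-c2cc(NC(=O)COCC(=O)N(C)CC(=O)NC(C)(C)C)nc(-c3ccc(OC)cc3)n2)cc1` is not yet measured. It differs from compound 2 by methyl in place of hydrogen on an amide-type nitrogen. Compound 1 already carries a methyl on a comparable amide nitrogen in its own chain, and compound 1 and compound 2 sit within the scatter of each other, so there is no sign that such a methyl moves the number far. For compound 3 the expected step, a 1.0-fold higher number from compound 2 to compound 3 (0.01 log units; within the scatter), is therefore none beyond the scatter, in no particular direction. The estimate for compound 3 in this assay is 20000 nM, with a range from 8000 nM to 50000 nM.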

Compound 3, inhibition constant: 19400 nM
The estimate for compound 3 lay 1.0-fold (0.01 log units) above the measured number, within the range that was stated.
By their numbers in this assay, from the lowest: compounds 3, 2 and 1 (each within the scatter of the next).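

Among the compounds shown here, the step of a 1.0-fold lower number from compound 2 to compound 3 (0.01 log units; within the scatter) in this assay is the first reading of this methyl on its own, as compound 2 and compound 3 differ in this one place only, whereas compound 1 has a different chain. It shows that, on the amide-type nitrogen whose other neighbours are the carbonyl carbon and a saturated chain carbon, exchanging the amide hydrogen for methyl gives no difference that can be told from the scatter in this series. Nothing at hand bears on why the reading comes out this way.

As far as these compounds go, whether a longer chain such as ethyl or propyl on this same nitrogen would read the same stays open, as does whether an amine or a carboxylic acid in place of the tert-butyl group would leave the methyl equally without effect. The pair also says nothing about methyl on any other nitrogen of the chain, so this reading holds for this one position alone.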